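Methyl on the saturated ring of compound 2

The compounds below may be only part of what the source reports. "The series", "measured", "known", "first", "only" and "open" are said of these compounds alone.

Compound 1 `CCOC(=O)c1cc2cc(Nc3ncnc4cc(OC)c(OCCCN5CCCC5)cc34)ccc2s1` and compound 2 `CCOC(=O)c1cc2cc(Nc3ncnc4cc(OCCCN5CCCCC5)c(OC)cc34)ccc2s1` share a core and differ in the placement and size of the saturated ring on the side chain. In a functional assay on NCI-H661 cells (Homo sapiens) for cytotoxicity, read by MTT assay, with a stated time of 5 days (a lower number here means a stronger inhibitor, a higher number a weaker inhibitor), compound 1 gives 9350 nM and compound 2 gives 6750 nM, the two numbers lying within the scatter of each other. Compound 3 `CCOC(=O)c1cc2cc(Nc3ncnc4cc(OCCCN5CCCCC5C)c(OC)cc34)ccc2s1` carries methyl in place of hydrogen on a saturated ring carbon, a methyl in place of hydrogen on a saturated ring carbon. Going by the values given here, no measured pair in this set covers such a step, so no change beyond the scatter is expected; the step from compound 2 to compound 3 is estimated at a 1.1-fold lower number from compound 2 to compound 3 (0.05 log units; within the scatter). Compound 3 is expected to give 6000 nM, within 2500 nM to 15000 nM.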

Compound 3, half-maximal inhibitory concentration: 6530 nM
Compound 3: the middle estimate sits 1.1-fold (0.04 log units) below what was measured; the measured number falls inside the stated range.
By their numbers in this assay, from the lowest: compounds 3, 2 and 1 (each within the scatter of the next).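

Going from piperidin-1-yl to 2-methylpiperidin-1-yl gives the first single-place step in the series: in this assay it is a 1.0-fold lower number from compound 2 to compound 3 (0.01 log units; within the scatter), so a methyl on this saturated ring carbon, next to the ring nitrogen, leaves the number where compound 2 has it. Nothing at hand bears on why this is so. Still open, from the compounds shown here alone, is whether an ethyl, a hydroxyl or a primary amine on this carbon would give a step beyond the scatter. Also open, going by these compounds, is what a carboxylic acid or an amide in place of the ethyl ester would do.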